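Benzylsulfanyl for dimethylamino on the shared core

A few compounds are considered here, and "the series" means these few. Any claim that something is new, unique, unknown or untested is made for them only; others in the source may bear on it.

The series shares the core of compound 1 `CNc1nc2cc(Cl)c(Cl)cc2n1COC(CO)CO`. In a functional assay on KB cells (Homo sapiens) for inhibition (a higher number here means a weaker inhibitor, a lower number a stronger inhibitor), compound 1 reaches only the limit of the assay, > 100000 nM. Compound 2 `CN(C)c1nc2cc(Cl)c(Cl)cc2n1COC(CO)CO` differs by methyl in place of hydrogen on a nitrogen on an aromatic ring. In this assay compound 2 likewise stops at the limit, > 100000 nM. The step that the two limits leave unreadable from compound 1 to compound 2 is therefore not readable in either direction. Both values shown sit at the same limit (the limit of > 100000 nM in this assay, at which 2 of the 2 values shown sit), so compound 2 stands at the limit and nowhere more definite: no number, only the statement that the inhibitory concentration lies beyond the range of this assay.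

Compound 3 `OCC(CO)OCn1c(SCc2ccccc2)nc2cc(Cl)c(Cl)cc21` carries benzylsulfanyl in place of dimethylamino on an aromatic carbon. Among the compounds with values here, no measured step bears on this change, because the only step available, a step that the two limits leave unreadable from compound 1 to compound 2, is unreadable. With both measured compounds at the limit, compound 3 is expected to return to the limit as well. The estimate for compound 3 in this assay is 100000 nM, with a range from 30000 nM to 300000 nM. The expected step is a number no higher from compound 2 to compound 3 (the limit leaves the size open), which cannot be separated from the scatter.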

Compound 3, half-maximal inhibitory concentration: > 100000 nM
Compound 3 ended at the assay's limit; the forecaster's own chance of this, stated with the estimate: 75%; the middle value lies on the limit itself.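

In this assay compound 3 gives > 100000 nM, which is a limit and not a number. No step among compound 1, compound 2 and compound 3 can be read, as all three stop at the same point: the limit of > 100000 nM in this assay, at which 3 of the 3 values shown sit.

The compounds shown leave open which group, if any, at this place on the shared core would bring the inhibitory concentration within the range of the assay.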